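The compounds below may be only part of what the source reports. "The series", "measured", "known", "first", "only" and "open" are said of these compounds alone.

Measured so far:
compound 1 `O=[N+]([O-])c1ccccc1/C=N\NC(=S)N(Cc1ccccc1)Cc1ccccc1`: < 155000 nM
compound 2 `C=CCN(CC=C)C(=S)N/N=C\c1ccccc1C`: > 228000 nM

In an ADME assay on Vero cells (Chlorocebus sabaeus) for cytotoxicity, read by MTT assay, with a stated time of 72 h (on this read-out lower numbers stand for higher toxicity in this test and higher numbers for lower toxicity in this test), compound 1 gives < 155000 nM, which is a limit of the assay rather than a number. Compound 2 gives > 228000 nM in this assay, again a limit and not a number. Compound 1 therefore stands at one of the two limits shown, the one named in the limit of < 155000 nM in this assay, at which 1 of the 2 values shown sits, while the other limit is the limit of > 228000 nM in this assay, at which 1 of the 2 values shown sits; with no number on either side, no measured step can be drawn between them.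

Compound 3 `O=[N+]([O-])c1ccc(/C=N\NC(=S)N(Cc2ccccc2)Cc2ccccc2)cc1` differs from compound 1 in a single place: 4-nitrophenyl in place of 2-nitrophenyl on a carbon with a double bond to nitrogen. Moving a group around one ring without changing the atoms is a small change on the measures shown here, so the step in this assay is expected to be none beyond the scatter, as a step that the limit leaves unreadable from compound 1 to compound 3 expresses. For compound 3 the expected value in this assay is 100000 nM, estimated within the range 30000 nM to 250000 nM.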

Compound 3, half-maximal cytotoxic concentration: < 155000 nM
Compound 3 gave a limit, no number; the forecaster's own chance of this, stated with the estimate: 50%; the middle value does not contradict the limit.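

Compound 1 and compound 3 each give a limit of the assay, not a number, and no step can be read between them. The compounds shown leave open whether 4-nitrophenyl in place of 2-nitrophenyl changes the result in this assay at all, and where the true value of either compound lies.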